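Adding a fluoro to compound 2

The source may hold more compounds than are shown below. What is called first, only, known or untested is meant among the compounds shown, and "the series" means these compounds.

In a functional assay on HCT-116 cells (Homo sapiens) for antiproliferative activity, with a stated time of 72 h (on this read-out higher numbers stand for weaker inhibition and lower numbers for stronger inhibition), compound 2 (`O=C(COc1ccc(CN2CC=C(c3c[nH]c4ccc(F)cc34)CC2)cc1)NO`) gives 949 nM, the highest of the three numbers and beyond the scatter from both others. Compound 1 (`O=C(COc1ccc(CNC2CC=C(c3c[nH]c4cccc(F)c34)CC2)c(F)c1)NO`) gives 173 nM and compound 3 (`Cc1[nH]c2ccccc2c1C1=CCC(NCc2ccc(OCC(=O)NO)cc2)CC1`) gives 184 nM, within the scatter of each other. Compound 4 (`O=C(COc1ccc(CN2CC=C(c3c[nH]c4ccc(F)cc34)CC2)c(F)c1)NO`) follows from compound 2 by fluoro in place of hydrogen on an aromatic carbon. Among the measured compounds shown here, no measured pair isolates this change: compound 1 carries a fluoro on that ring at 173 nM, while compound 3 has none at 184 nM. In this assay, no step beyond the scatter is expected, with a slight lean towards a lower number. The expected move is a 1.4-fold lower number from compound 2 to compound 4 (0.13 log units; within the scatter). For compound 4 the estimate is 700 nM, with an expected range of 300 nM to 1500 nM.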

Compound 4, half-maximal inhibitory concentration: > 5000 nM
Compound 4 ended at the assay's limit; the forecaster's own chance of this, stated with the estimate: 1%; middle value at least 7.1-fold (0.85 log units) from the limit.
By their numbers in this assay, from the lowest: compounds 1 and 3 (each within the scatter of the next); then compound 2. At a limit, above all of these: compound 4.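

In this assay, fluoro in place of hydrogen on this aromatic carbon, ortho to a large group and meta to the (hydroxycarbamoyl)methoxy group, gives an at least 5.2-fold higher number from compound 2 to compound 4 (0.72 log units; beyond the scatter). On the background of compound 2, this single-atom change at this position is therefore enough to weaken inhibition beyond the scatter. Compound 4 stands at a limit of the assay, not at a number: the limit of > 5000 nM in this assay, at which 1 of the 4 values shown sits.

As far as these compounds go, whether a chloro or a methyl group at this position gives the same result remains open. So does whether a methoxy group on this carbon does.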